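The compounds below may be only part of what the source reports. "The series", "measured", "known", "first", "only" and "open" are said of these compounds alone.

The shared core of compound 1 `Cc1cc(NC(=O)Nc2ccc(C)c(Cl)c2)c2ccccc2n1` recurs in compound 2 `Cc1cc(NC(=O)Nc2ncccc2C)c2ccccc2n1` and compound 3 `Cc1cc(NC(=O)Nc2ccccc2F)c2ccccc2n1`, the three differing only in the group on the amide-type nitrogen. In an ADME assay on HepG2 cells (Homo sapiens) for cytotoxicity, with a stated time of 72 h (a lower number here means that less compound is needed, a higher number that more compound is needed for the effect), compound 1 gives only a limit, > 25000 nM. Compound 2 likewise returns a limit in this assay, > 25000 nM. Compound 3 also stops at a limit in this assay, > 25000 nM. Among the measured compounds shown here, the single one-site step among them, a step that the two limits leave unreadable from compound 2 to compound 3, cannot be sized, as both ends are limits. Compound 3 therefore stands at the limit of > 25000 nM in this assay, at which 3 of the 3 values shown sit, with no number to set it apart from compound 1 or compound 2.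

Compound 4 `Cc1cc(NC(=O)Nc2cccc(Cl)c2)c2ccccc2n1` follows by one change: 3-chlorophenyl in place of 2-fluorophenyl on an amide-type nitrogen. For the measured compounds named here, no measured step offers a readable size for a change of this kind; the only comparison at hand, a step that the two limits leave unreadable from compound 2 to compound 3, is unreadable. Everything measured so far sits at the limit of > 25000 nM in this assay, at which 3 of the 3 values shown sit, and nothing in it points to a step in this assay that would carry compound 4 under that limit. The step that the limit leaves unreadable from compound 3 to compound 4 in this assay is thus expected to be negligible, with the assay most likely again reporting only a limit. The estimate for compound 4 in this assay is 40000 nM, within a range from 20000 nM to 100000 nM.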

Compound 4, half-maximal effective concentration: 19000 nM
Beside the measured number, compound 4's estimate is 2.1-fold (0.32 log units) above it; the measured number lies below the stated range.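

In this assay compound 4 is the only one of the four compounds shown to return a number rather than a limit, so a readable value now attaches to one group on the amide-type nitrogen, 3-chlorophenyl. Putting 3-chlorophenyl in place of 2-fluorophenyl gives an at least 1.3-fold lower number from compound 3 to compound 4 (0.11 log units; that floor lies within the scatter), putting it in place of 3-methylpyridin-2-yl gives an at least 1.3-fold lower number from compound 2 to compound 4 (0.11 log units; that floor lies within the scatter), and hydrogen in place of methyl on an aromatic carbon gives an at least 1.3-fold lower number from compound 1 to compound 4 (0.11 log units; that floor lies within the scatter); each of these is only a floor, and none shows a change beyond the scatter. The new number therefore marks a value close to the limit rather than a measured distance from the other compounds, which still stand at that limit: the limit of > 25000 nM in this assay, at which 3 of the 4 values shown sit.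

Going by these compounds, how far compound 1, compound 2 and compound 3 truly lie from compound 4 stays open, and the step between compound 2 and compound 3 cannot be read at all. The compounds shown also leave open whether an amine or a carboxylic acid in place of the chlorine of 3-chlorophenyl would bring the number further down in this assay.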